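The source may report more compounds than this note shows. Statements on the series, on what has been measured and on what is new or still open speak of the compounds shown alone.

Measured compounds in the series:

compound 1, `Cc1ccccc1COc1ccc(-c2cc(CN3CCN(Cc4ccc(C(F)(F)F)cc4)CC3)no2)cc1` — 1200 nM
compound 2, `N#Cc1cccc(COc2ccc(-c3cc(CN4CCN(c5ccc(F)cc5)CC4)no3)cc2)c1` — 1500 nM

Both values come from a functional assay on Huh-7 cells (Homo sapiens) for antiproliferative activity, read by sulforhodamine B assay, with a stated time of 72 h; a lower number here means a stronger inhibitor, a higher number a weaker inhibitor. Compound 2 gives the higher of the two numbers, but its gap to compound 1 is within the scatter, so the two compounds are not separated by this assay. Compound 1 carries a benzyl-type substituent on the ring amine nitrogen, compound 2 an aryl substituent, and the numbers do not tell the two apart.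

Compound 3, `N#Cc1cccc(COc2ccc(-c3cc(CN4CCN(Cc5cccc(F)c5)CC4)no3)cc2)c1`, has not yet been measured in this assay. It differs from compound 2 in one place: 3-fluorobenzyl in place of 4-fluorophenyl on an amine nitrogen in a ring. Among the measured compounds shown here, no step between measured compounds isolates this change. For the measured compounds named here, the only guidance is that compound 1 and compound 2 sit together, so a step from compound 2 to compound 3 of no more than the scatter is expected, in either direction. For compound 3 an estimated value of 1300 nM is expected, in the range 450 nM to 3800 nM, meaning an expected step of a 1.2-fold lower number from compound 2 to compound 3 (0.06 log units; within the scatter).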

Compound 3, half-maximal inhibitory concentration: 2700 nM
Beside the measured number, compound 3's estimate is 2.1-fold (0.32 log units) below it; measured number inside the range.
By their numbers in this assay, from the lowest: compounds 1, 2 and 3 (each within the scatter of the next, the first and the last beyond it).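

In this assay, the swap of 3-fluorobenzyl in place of 4-fluorophenyl on an amine nitrogen in a ring gives a 1.8-fold higher number from compound 2 to compound 3 (0.26 log units; within the scatter), within the scatter, so this change does not separate the pair. Among the compounds shown here, this is the first reading of the change with the rest of the structure held constant, and it shows that this position tolerates either substituent without a change that can be distinguished in this assay. No supporting measurement bears on this result.

The compounds shown leave open whether the fluorine or its place on the ring matters, since neither is varied alone in this pair. Also open, on these data alone, is how an unsubstituted benzyl, a 2-phenylethyl chain or an acyl group would behave on the same nitrogen.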